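Chloro on the Benzhydryl Phenyl: an Expected Small Step

A few compounds are considered here, and "the series" means these few. Any claim that something is new, unique, unknown or untested is made for them only; others in the source may bear on it.

Measured compounds:
compound 1 `COC(=O)CC/C(C)=C/Cc1c(OC)c(C)c2c(c1OCC#CCN1CCN(C(c3ccccc3)c3ccccc3)CC1)C(=O)OC2` – 23700 nM
compound 2 `COC(=O)CC/C(C)=C/Cc1c(OC)c(C)c2c(c1OCC#CCN1CCN(c3ccc(O)cc3)CC1)C(=O)OC2` – 46100 nM

In a functional assay on SH-SY5Y cells (Homo sapiens) for inhibition, read by sulforhodamine B assay (a lower number here means a stronger inhibitor, a higher number a weaker inhibitor), compound 1 gives 23700 nM, the lowest of the two numbers shown, while compound 2 gives 46100 nM, a gap within the scatter. Compound 3 `COC(=O)CC/C(C)=C/Cc1c(OC)c(C)c2c(c1OCC#CCN1CCN(C(c3ccccc3)c3ccc(Cl)cc3)CC1)C(=O)OC2` is not yet measured. It differs from compound 1 by chloro in place of hydrogen on an aromatic carbon. For the measured compounds named here, no step between measured compounds is known, so the expected step is small: a 1.3-fold lower number from compound 1 to compound 3 (0.12 log units; within the scatter) is estimated to lie within the scatter, in either direction. Compound 3 is therefore expected to give about 18000 nM, within 7000 nM to 50000 nM.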

Compound 3, half-maximal inhibitory concentration: 9900 nM
Compound 3: the middle estimate sits 1.8-fold (0.26 log units) above what was measured; the range from low to high includes it.
By their numbers in this assay, from the lowest: compound 3; then compounds 1 and 2 (each within the scatter of the next).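

For the compounds shown here, replacing phenyl with 4-chlorophenyl gives a step in this assay that the earlier compounds could not show, a 2.4-fold lower number from compound 1 to compound 3 (0.38 log units; beyond the scatter), and it is a modest one. This aromatic carbon of the benzhydryl group therefore responds to a single chlorine atom, with the number moving lower. No measurement at hand accounts for this step.

On these data alone, whether fluoro, methoxy or an amine at the same carbon would move the number in the same direction remains open. So does whether a second chloro on the other phenyl ring would lower it further.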